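Series notes: replacing the hydroxyphenyl of compound 3

The source may hold more compounds than are shown below. What is called first, only, known or untested is meant among the compounds shown, and "the series" means these compounds.

Compound 1 `Cc1cccc(NC(=O)CN2CCC(c3nccs3)CC2)c1` gives 1 nM in a functional assay on HEK293 cells for agonist activity at D(4) dopamine receptor (Homo sapiens), read by FLIPR; a higher number here means that more compound is needed for the effect, a lower number that less compound is needed. Compound 2 `Cc1cccc(NC(=O)CN2CCC(c3cccc(F)c3)CC2)c1` gives 512 nM in this assay, and compound 3 `Cc1cccc(NC(=O)CN2CCC(c3cccc(O)c3)CC2)c1` gives 8 nM in this assay. Compound 3 thus stands second highest of the three numbers: an 8.0-fold higher number from compound 1 to compound 3 (0.90 log units; beyond the scatter) places it nearest to compound 1, while a 64-fold lower number from compound 2 to compound 3 (1.81 log units; beyond the scatter) places it furthest from compound 2.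

Compound 4 `Cc1cccc(NC(=O)CN2CCC(c3ccccc3C)CC2)c1` carries 2-methylphenyl in place of 3-hydroxyphenyl on a saturated ring carbon. Among the compounds with values here, two measured steps bear on this change. a 64-fold lower number from compound 2 to compound 3 (1.81 log units; beyond the scatter) shows what the hydroxy on the aromatic carbon was worth against fluoro, and a 510-fold higher number from compound 1 to compound 2 (2.71 log units; beyond the scatter) shows where a six-membered carbon ring without hydrogen-bond donors or acceptors landed against the 1,3-thiazol-2-yl. The 2-methylphenyl likewise brings 0 hydrogen-bond donors and 0 hydrogen-bond acceptors, though with its methyl on a carbon not tested in this set, so the step in this assay is expected to be upward and large but uncertain: a 25-fold higher number from compound 3 to compound 4 (1.40 log units; beyond the scatter) is the expectation. Compound 4 is accordingly estimated at 200 nM, with a range of 30 nM to 1500 nM.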

Compound 4, half-maximal effective concentration: 340 nM
Compound 4: middle estimate off by 1.7-fold (0.23 log units), on the low side; measured number inside the range.
By their numbers in this assay, from the lowest: compound 1; then compound 3; then compounds 4 and 2 (each within the scatter of the next).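

In this assay, a 43-fold higher number from compound 3 to compound 4 (1.63 log units; beyond the scatter), so a second carbon-only phenyl group, the 2-methylphenyl with 0 hydrogen-bond donors and 0 hydrogen-bond acceptors, also fails to match the 3-hydroxyphenyl at this saturated ring carbon. With a 1.5-fold lower number from compound 2 to compound 4 (0.18 log units; within the scatter), the 2-methylphenyl and 3-fluorophenyl cannot be ordered, while a 340-fold higher number from compound 1 to compound 4 (2.53 log units; beyond the scatter) keeps the gap to the 1,3-thiazol-2-yl large, and compound 1, which carries no hydroxy, goes against any reading that a hydroxy is required at this position. No supporting data bear on why these groups differ.

Still open, from the compounds shown here alone, is whether 3-methylphenyl or 2-hydroxyphenyl would separate the effect of the group from that of its placement on the phenyl ring. Going by these compounds, it is also open whether an aminophenyl or hydroxymethylphenyl would hold a number near that of compound 3 .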